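Swapping the halogenated acyl ring in an acylurea series

The source may report more compounds than this note shows. Statements on the series, on what has been measured and on what is new or still open speak of the compounds shown alone.

Compound 1, `Cc1nc(N(C)C(=O)NC(=O)c2c(F)cccc2F)sc1C(=O)N/N=C/c1ccc(C(F)(F)F)cc1`: 60.5 ug/mL
Compound 2, `CN(C(=O)NC(=O)c1ccc(Cl)cc1Cl)c1nc(C(F)(F)F)c(C(=O)N/N=C/c2ccc(C(F)(F)F)cc2)s1`: 9.4 ug/mL
Compound 3, `Cc1nc(N(C)C(=O)NC(=O)c2c(F)cccc2F)sc1C(=O)N/N=C/c1ccccc1C(F)(F)F`: 5.43 ug/mL

All three numbers come from a functional assay on A549 cells (Homo sapiens) for inhibition, read by MTT assay, with a stated time of 72 h; a higher number here means a weaker inhibitor, a lower number a stronger inhibitor. Compound 2 stands second highest of the three. Its nearest neighbour is compound 3, and the gap between them lies within the scatter of repeated measurements, so no order between compound 2 and compound 3 can be claimed. Its furthest neighbour is compound 1, whose higher number lies beyond the scatter. Among the compounds with values here, the one measured step, an 11-fold lower number from compound 1 to compound 3 (1.05 log units; beyond the scatter), concerns the ring attached to the carbon bearing a double bond to nitrogen, not the ring on the carbonyl.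

Compound 4, `CN(C(=O)NC(=O)c1ccc(F)c(F)c1)c1nc(C(F)(F)F)c(C(=O)N/N=C/c2ccc(C(F)(F)F)cc2)s1`, is not yet measured. It differs from compound 2 as follows: 3,4-difluorophenyl in place of 2,4-dichlorophenyl on a carbonyl carbon. Within the data shown here, no measured pair changes this carbonyl-attached ring on its own, so the step cannot be anchored on data. Compound 2 and compound 3 carry different carbonyl rings along with other differences and still lie within the scatter of each other, which is a weak hint that differing groups there can give similar numbers. On that basis compound 4 is expected to show a 1.0-fold lower number from compound 2 to compound 4 (0.02 log units; within the scatter), a step not beyond the scatter. The estimate for compound 4 in this assay is 9 ug/mL, with a range from 3 ug/mL to 30 ug/mL.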

Compound 4, half-maximal inhibitory concentration: 6.07 ug/mL
Estimate against measurement, compound 4: 1.5-fold (0.17 log units) above, within the range that was stated.
By their numbers in this assay, from the lowest: compounds 3, 4 and 2 (each within the scatter of the next); then compound 1.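

In this assay, within the data shown here, the swap of the ring on the carbonyl carbon, whose other neighbour is the amide-type nitrogen, gives a 1.5-fold lower number from compound 2 to compound 4 (0.19 log units; within the scatter) and so offers the only direct reading at this position: 3,4-difluorophenyl and 2,4-dichlorophenyl cannot be told apart here. The step at the other ring, an 11-fold lower number from compound 1 to compound 3 (1.05 log units; beyond the scatter) in a different compound pair, stands beyond the scatter, so the shown data contain a clear difference at that ring but none at the carbonyl ring, although one swap at each place is thin ground for ranking the two positions. Nothing measured here bears on why these two rings read alike.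

This swap altered the halogen and its placement together, so a single pair cannot separate the two, and 3,4-dichlorophenyl would be the group that pulls them apart. Every ring on the carbonyl shown carries halogens, which leaves open how an unsubstituted phenyl, or a phenyl bearing an amine or a carboxylic acid, would read at this position.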